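Swapping Chloro for Bromo: A Small Step Expected

The source may report more compounds than this note shows. Statements on the series, on what has been measured and on what is new or still open speak of the compounds shown alone.

Compound 3 `CC(=O)Nc1ccc(S(=O)(=O)NNc2ccc(Cl)cc2)cc1` gives 142 nM in an assay on HeLa cells for inhibition of Indoleamine 2,3-dioxygenase 1 (Homo sapiens), read by spectrophotometry, with a stated time of 24 h (a higher number here means that more compound is needed for the effect, a lower number that less compound is needed), the lowest of the two numbers shown. Compound 2 `CC(=O)Nc1ccc(S(=O)(=O)NNc2ccc(S(N)(=O)=O)cc2)cc1` gives 3120 nM, a result that is a 22-fold lower number from compound 2 to compound 3 (1.34 log units; beyond the scatter). Compound 1 `CC(=O)Nc1ccc(S(=O)(=O)NNc2ccccc2)cc1` gives only a limit in this assay, > 10000 nM. Compound 4 `CC(=O)Nc1ccc(S(=O)(=O)NNc2ccc(Br)cc2)cc1` differs from compound 3 by bromo in place of chloro on an aromatic carbon. The measured steps that bear on this exchange are an at least 70-fold lower number from compound 1 to compound 3 (1.84 log units; beyond the scatter) and a 22-fold lower number from compound 2 to compound 3 (1.34 log units; beyond the scatter), both showing that chloro at this place brings a large gain over hydrogen and over sulfamoyl. Chloro to bromo is a far smaller exchange than either of those, so compound 4 is expected to stay close to compound 3, with no step beyond the scatter. The step expected for compound 4 is a 1.1-fold lower number from compound 3 to compound 4 (0.04 log units; within the scatter). Compound 4 is estimated at 130 nM, between 60 nM and 300 nM.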

Compound 4, half-maximal effective concentration: 85 nM
Beside the measured number, compound 4's estimate is 1.5-fold (0.18 log units) above it; the range from low to high includes it.
By their numbers in this assay, from the lowest: compounds 4 and 3 (each within the scatter of the next); then compound 2. At a limit, above all of these: compound 1.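

In this assay, exchanging chloro for bromo at this place gives a 1.7-fold lower number from compound 3 to compound 4 (0.22 log units; within the scatter), so the two groups cannot be told apart here. The advantage over sulfamoyl holds with bromo as well, at a 37-fold lower number from compound 2 to compound 4 (1.56 log units; beyond the scatter). The comparison with hydrogen reads an at least 110-fold lower number from compound 1 to compound 4 (2.07 log units; beyond the scatter), and it rests on compound 1, whose value is only a limit: the limit of > 10000 nM in this assay, at which 1 of the 4 values shown sits.

The compounds shown leave open how fluoro, methyl or methoxy would fare at this place. They also leave open whether an amine or a carboxylic acid there would resemble sulfamoyl rather than chloro and bromo.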